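The compounds below may be only part of what the source reports. "The series", "measured", "known", "first", "only" and "open" are said of these compounds alone.

Among the compounds with values here, compound 2, `CC(F)(F)c1cccc(N2C(=O)CSC2c2cccc(C(=O)NCCCCc3ccccc3)c2)c1`, is one of two compounds measured so far in a functional assay on HOS-TE85 cells (Homo sapiens) for inhibition, read by CCK-8 assay, with a stated time of 72 h, tested at 1 uM; on this read-out higher numbers stand for more inhibition at the one concentration tested (going by the name of the read-out) and lower numbers for less inhibition. In this assay compound 2 gives 93%, while compound 1, `Cc1cccc(N2C(=O)CSC2c2cccc(C(=O)NCCCCc3ccccc3)c2)c1`, gives 96%. Within the data shown here, the two numbers lie within the scatter of each other, so neither can be ranked against the other; the only step known, a number 3 percentage points lower from compound 1 to compound 2 (within the scatter), was a change on the aromatic ring carried by the amide-type nitrogen in the ring. Compound 3, `COc1c(F)cccc1N1C(=O)CSC1c1cccc(C(=O)NCCCCc2ccccc2)c1`, is not yet measured. It differs from compound 2 as follows: a group of 9 heavy atoms (7 carbon, 1 oxygen, 1 fluorine; one six-membered aromatic ring of carbon only) in place of a group of 10 heavy atoms (8 carbon, 2 fluorine; one six-membered aromatic ring of carbon only), on an amide-type nitrogen in a ring. Among the measured compounds shown here, this change sits at the same position as the one from compound 1 to compound 2, and the group that enters is again a substituted six-membered aromatic ring of carbon only. Because a number 3 percentage points lower from compound 1 to compound 2 (within the scatter) stayed within the scatter, the step to compound 3 in this assay is expected to stay within the scatter as well, with a number 1 percentage points lower from compound 2 to compound 3 (within the scatter) as the estimate. Compound 3 is therefore expected to give about 92% in this assay, within a range from 80% to 98%.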

Compound 3, a percentage reported as inhibition, at one concentration (the size of the read-out at that concentration, not a potency): 12%
Compound 3: the middle estimate sits 80 percentage points above what was measured, and the stated range ends above it.
By their numbers in this assay, from the lowest: compound 3; then compounds 2 and 1 (each within the scatter of the next).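

Compound 3 shows that this position, on the amide-type nitrogen in a ring, does not accept every substituted six-membered aromatic ring alike: in this assay the exchange gives a number 81 percentage points lower from compound 2 to compound 3 (beyond the scatter), and the comparison with the 3-methylphenyl group gives a number 84 percentage points lower from compound 1 to compound 3 (beyond the scatter). The earlier change from methyl to 1,1-difluoroethyl had not revealed this sensitivity, so the small step seen there cannot be carried over to the 3-fluoro-2-methoxyphenyl group, which differs from the groups before it in its substituents and, by count, in bringing 1 hydrogen-bond acceptor where the group of compound 2 has 0. Nothing at hand explains why the read-out falls so far with this group.

The 3-fluoro-2-methoxyphenyl group carries both a methoxy group and a fluorine, so the compounds shown do not tell whether one of these alone, or only the two together, goes with the low number. As far as these compounds go, it also remains open how a ring carrying only a methoxy group, only a fluorine, or a different substituent such as a dimethylamino group or a nitrile would read at this position.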